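A few compounds are considered here, and "the series" means these few. Any claim that something is new, unique, unknown or untested is made for them only; others in the source may bear on it.

Compound 1 `O=C(Nc1ccc(F)cc1)c1ccc(C(=O)O)nc1` — 16100 nM
Compound 2 `CN(C)c1ccc(NC(=O)c2ccc(C(=O)O)nc2)cc1` — 4100 nM
Compound 3 `COc1ccc(NC(=O)c2ccc(C(=O)O)nc2)cc1` — 21100 nM

In an assay on isolated protein (Gallus gallus) for inhibition of transmembrane prolyl 4-hydroxylase (Homo sapiens) (a higher number here means a weaker inhibitor, a lower number a stronger inhibitor), compound 3 gives 21100 nM; compound 1 differs from it only within the scatter (a 1.3-fold higher number from compound 1 to compound 3 (0.12 log units; within the scatter)), while compound 2 lies beyond it (a 5.1-fold higher number from compound 2 to compound 3 (0.71 log units; beyond the scatter)). Compound 4 `O=C(Nc1ccc([N+](=O)[O-])cc1)c1ccc(C(=O)O)nc1` is not yet measured and differs from compound 3 by nitro in place of methoxy on an aromatic carbon. Among the measured compounds shown here, no measured step exchanges a nitro, so none bears on it directly. The measured steps at this aromatic carbon, a 3.9-fold lower number from compound 1 to compound 2 (0.59 log units; beyond the scatter) and a 1.3-fold higher number from compound 1 to compound 3 (0.12 log units; within the scatter), show one replacement that lowered the number and one that stayed within the scatter. Without a closer precedent, the step expected for compound 4 is a 1.2-fold lower number from compound 3 to compound 4 (0.07 log units; within the scatter), essentially no change beyond the scatter. The estimate for compound 4 is therefore 18000 nM, with a range of 6000 nM to 50000 nM.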

Compound 4, half-maximal inhibitory concentration: 44000 nM
Compound 4: the middle estimate sits 2.4-fold (0.39 log units) below what was measured, and the stated range covers the measured number.
By their numbers in this assay, from the lowest: compound 2; then compounds 1 and 3 (each within the scatter of the next); then compound 4.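

In this assay, among the compounds shown here, nitro is the only group at this aromatic carbon that lies beyond the scatter on the high side of both fluoro (a 2.7-fold higher number from compound 1 to compound 4 (0.44 log units; beyond the scatter)) and methoxy (a 2.1-fold higher number from compound 3 to compound 4 (0.32 log units; beyond the scatter)). The gap to dimethylamino is the widest in the set (an 11-fold higher number from compound 2 to compound 4 (1.03 log units; beyond the scatter)), so the four groups now fall into three levels, with fluoro and methoxy together in the middle. Nothing at hand accounts for this order.

Going by these compounds, whether a primary amine, a hydroxyl or a trifluoromethyl at this carbon would fall inside or outside this range remains open. So does whether the same order holds on a different core.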